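The source may report more compounds than this note shows. Statements on the series, on what has been measured and on what is new or still open speak of the compounds shown alone.

Measured so far in a functional assay on MDA-MB-231 cells (Homo sapiens) for antiproliferative activity, read by MTT assay, with a stated time of 72 h; on this read-out lower numbers stand for stronger inhibition and higher numbers for weaker inhibition:
compound 1 `NS(=O)(=O)c1ccc(NC(=O)Nc2cccc(-c3nc(-c4ccc(NC(=O)c5cccnc5)cc4Cl)no3)c2)cc1`: > 10000 nM, a limit of the assay rather than a number.
compound 2 `O=C(Nc1cccc(-c2nc(-c3ccc(NC(=O)c4cccnc4)cc3Cl)no2)c1)Nc1ccc(Cl)c(C(F)(F)F)c1`: 1900 nM.
compound 3 `C#Cc1ccc(NC(=O)Nc2cccc(-c3nc(-c4ccc(NC(=O)c5cccnc5)cc4Cl)no3)c2)cc1`: > 10000 nM, again only a limit.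

Compound 3 thus stands at the limit, together with compound 1, as noted in the limit of > 10000 nM in this assay, at which 2 of the 3 values shown sit. The step to compound 4 `CS(=O)(=O)Nc1ccc(NC(=O)Nc2cccc(-c3nc(-c4ccc(NC(=O)c5cccnc5)cc4Cl)no3)c2)cc1` is methanesulfonamido in place of ethynyl on an aromatic carbon. Within the data shown here, no measured step covers this change directly. The step of an at least 5.2-fold higher number from compound 2 to compound 3 (0.72 log units; beyond the scatter) and the step of an at least 5.2-fold lower number from compound 1 to compound 2 (0.72 log units; beyond the scatter) show that only the 4-chloro-3-(trifluoromethyl)phenyl group gave a readable number, while the sulfamoyl analogue compound 1 and the ethynyl analogue compound 3 both sit at the limit. Compound 4 is therefore expected to remain at or near the limit, with no step beyond the scatter. The expected change is a step that the limit leaves unreadable from compound 3 to compound 4. Compound 4 is estimated at 15000 nM, within 5000 nM to 50000 nM.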

Compound 4, half-maximal inhibitory concentration: 600 nM
Compound 4: middle estimate off by 25-fold (1.40 log units), on the high side, outside the stated range (below it).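

In this assay, methanesulfonamido on this aromatic carbon gives an at least 16-fold lower number from compound 3 to compound 4 (1.22 log units; beyond the scatter) and an at least 16-fold lower number from compound 1 to compound 4 (1.22 log units; beyond the scatter), so a readable number at this position does not require the 4-chloro-3-(trifluoromethyl)phenyl group. The same change also improves on that group, with a 3.2-fold lower number from compound 2 to compound 4 (0.50 log units; beyond the scatter). The first two steps are bounded on one side only: the limit of > 10000 nM in this assay, at which 2 of the 4 values shown sit.

Open, as far as these compounds go, is whether an acetamido or ethanesulfonamido group at this position would keep the number. A carboxylic acid or an amine there also remains untested in the compounds shown.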